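The source may report more compounds than this note shows. Statements on the series, on what has been measured and on what is new or still open speak of the compounds shown alone.

Measured so far in an ADME assay on WI-38 cells (Homo sapiens) for cytotoxicity, read by MTT assay, with a stated time of 72 h; on this read-out higher numbers stand for weaker inhibition and lower numbers for stronger inhibition:
compound 1 `CN(C)CCn1cnnc1-c1cc(Oc2ccc(NC(=O)Nc3cccc(C(F)(F)F)c3)cc2F)ccn1` gives 11200 nM
compound 3 `CCN(CC)CCn1cnnc1-c1cc(Oc2ccc(NC(=O)Nc3cccc(C(F)(F)F)c3)cc2F)ccn1` gives 6920 nM
Compound 2 `CN(C)CCn1cnnc1-c1cc(Oc2ccc(NC(=O)Nc3ccccc3C(F)(F)F)cc2F)ccn1` reaches only a limit of the assay, reported as > 50000 nM.

Compound 4 `CCN(CC)CCn1cnnc1-c1cc(Oc2ccc(NC(=O)Nc3ccccc3C(F)(F)F)cc2F)ccn1` is not yet measured. Compound 3 and compound 4 differ by 2-(trifluoromethyl)phenyl in place of 3-(trifluoromethyl)phenyl on an amide-type nitrogen. The same change has been made once already, from compound 1 to compound 2: 2-(trifluoromethyl)phenyl in place of 3-(trifluoromethyl)phenyl on an amide-type nitrogen, giving an at least 4.4-fold higher number from compound 1 to compound 2 (0.64 log units; beyond the scatter); that step is capped by the limit of > 50000 nM in this assay, at which 1 of the 3 values shown sits. The two cores differ by diethylamino in place of dimethylamino on a saturated chain carbon, two bonds along the chain from an aromatic nitrogen, which gave a 1.6-fold lower number from compound 1 to compound 3 (0.21 log units; within the scatter). Since the place of the change is the same in both pairs, the step from compound 3 to compound 4 is expected to resemble the earlier one, a 5.8-fold higher number from compound 3 to compound 4 (0.76 log units; beyond the scatter), resting on an at least 4.4-fold higher number from compound 1 to compound 2 (0.64 log units; beyond the scatter). Compound 4 is therefore estimated at about 40000 nM, expected between 20000 nM and 90000 nM, and may well return only as a limit of this assay.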

Compound 4, half-maximal inhibitory concentration: 23500 nM
The estimate for compound 4 lay 1.7-fold (0.23 log units) above the measured number, within the range that was stated.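

In this assay, 2-(trifluoromethyl)phenyl in place of 3-(trifluoromethyl)phenyl on the amide-type nitrogen gives a 3.4-fold higher number from compound 3 to compound 4 (0.53 log units; beyond the scatter), so the direction of the change carries from the core of compound 1 to the core of compound 3: the same change on two cores in this assay, an at least 4.4-fold higher number (0.64 log units; beyond the scatter) from compound 1 to compound 2 and a 3.4-fold higher number (0.53 log units; beyond the scatter) from compound 3 to compound 4; the limit leaves it open whether they differ

Diethylamino in place of dimethylamino gives an at least 2.1-fold lower number from compound 2 to compound 4 (0.32 log units; beyond the scatter), which does not establish that this second change differs between the two cores: the same change on two cores in this assay, a 1.6-fold lower number (0.21 log units; within the scatter) from compound 1 to compound 3 and an at least 2.1-fold lower number (0.32 log units; beyond the scatter) from compound 2 to compound 4; the limit leaves it open whether they differ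

Compound 2 gives > 50000 nM, which is a limit, so only the direction of the first change is shown to carry over, not its size: the limit of > 50000 nM in this assay, at which 1 of the 4 values shown sits.

The compounds shown leave open whether the pattern holds with a morpholine or a piperidine in place of diethylamino, or with a longer chain. Going by these compounds, how 4-(trifluoromethyl)phenyl would read on the amide-type nitrogen also stays open.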